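The source may hold more compounds than are shown below. What is called first, only, known or untested is meant among the compounds shown, and "the series" means these compounds.

Of the compounds shown here, two sharing one core have been measured in a functional assay on MCF7 cells (Homo sapiens) for cytotoxicity, read by WST assay, with a stated time of 72 h; on this read-out lower numbers stand for stronger inhibition and higher numbers for weaker inhibition. Compound 1 `Cc1ccc(C2(c3ccc(O)cc3)C(=O)Nc3c2ccc(F)c3F)cc1` gives 1.7 nM, and compound 2 `CCOc1ccc(C2(c3ccc(O)cc3)C(=O)Nc3c2ccc(F)c3F)cc1` gives 11 nM, the higher of the two numbers. Going by the values given here, the single measured step, with ethoxy in place of methyl on an aromatic carbon, is a 6.5-fold higher number from compound 1 to compound 2 (0.81 log units; beyond the scatter).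

The next compound, compound 3 `O=C1Nc2c(ccc(F)c2F)C1(c1ccc(O)cc1)c1cccs1`, differs from compound 2 by thiophen-2-yl in place of 4-ethoxyphenyl on a saturated ring carbon. Among the compounds with values here, no measured step exchanges this aromatic ring itself, so the evidence is indirect. Only the ethoxy group links the two changes, since it departs with the 4-ethoxyphenyl group, and its presence in compound 2 went with a 6.5-fold higher number from compound 1 to compound 2 (0.81 log units; beyond the scatter). This points to a modest move towards a lower number in this assay, though the effect of thiophen-2-yl has not been measured in this set and the move may stay within the scatter. The expected change is a 2.2-fold lower number from compound 2 to compound 3 (0.34 log units; beyond the scatter). For compound 3 the estimated half-maximal inhibitory concentration is 5 nM, with an expected range of 1.2 nM to 25 nM.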

Compound 3, half-maximal inhibitory concentration: 82 nM
The estimate for compound 3 lay 16-fold (1.21 log units) below the measured number; the measured number lies above the stated range.
By their numbers in this assay, from the lowest: compound 1; then compound 2; then compound 3.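

In this assay, the exchange of 4-ethoxyphenyl for thiophen-2-yl on the saturated ring carbon gives a 7.5-fold higher number from compound 2 to compound 3 (0.87 log units; beyond the scatter), so the loss of the ethoxy group does not bring the number down: this position responds to more than the group carried on the six-membered aromatic ring. Set against the 4-methylphenyl group, thiophen-2-yl gives a 48-fold higher number from compound 1 to compound 3 (1.68 log units; beyond the scatter), the largest step among the three compounds, and both six-membered aromatic rings with a group attached give lower numbers here than the five-membered ring with its sulfur atom. Nothing available bears on why this exchange raises the number.

The three compounds do not separate the effect of the ring itself from that of losing the group attached to it, a question that a plain phenyl ring or a thiophen-2-yl ring carrying a methyl group would address. From the compounds shown here alone, how other replacements at this position would behave, such as a pyridine ring or a longer alkoxy chain on the six-membered ring, also stays open.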